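The source may report more compounds than this note shows. Statements on the series, on what has been measured and on what is new or still open speak of the compounds shown alone.

Going by the values given here, in a functional assay on PC-3 cells (Homo sapiens) for cytotoxicity, read by MTT assay, with a stated time of 72 h (on this read-out higher numbers stand for weaker inhibition and lower numbers for stronger inhibition), only two compounds carry a result so far. Compound 1 `COc1ccc(Nc2nc3ccccc3nc2S(=O)(=O)c2ccc(C)cc2)cc1` returns a limit of the assay, > 50000 nM. Among the compounds with values here, compound 2 `COc1ccc(Nc2nc3ccccc3nc2S(=O)(=O)c2ccc(Br)cc2)cc1` gives 1110 nM, the one measured number in the set, so it stands as the sole fixed point. Within the data shown here, the only measured change, an at least 45-fold lower number from compound 1 to compound 2 (1.65 log units; beyond the scatter), is large. Compound 3 `COc1ccc(Nc2nc3ccccc3nc2S(=O)(=O)c2ccc(F)cc2)cc1` has not yet been measured; it differs from compound 2 by fluoro in place of bromo on an aromatic carbon. Among the measured compounds shown here, no measured step covers an exchange of one halogen for another. For the measured compounds named here, the single step that touches the same place, an at least 45-fold lower number from compound 1 to compound 2 (1.65 log units; beyond the scatter), shows that the group there can move the number across a wide range. Compound 1 sits at the limit (the limit of > 50000 nM in this assay, at which 1 of the 2 values shown sits). Fluoro lies outside either measured case, so for compound 3 the expected step is estimated as a 5.4-fold higher number from compound 2 to compound 3 (0.73 log units; beyond the scatter), a sizeable shift toward weaker inhibition that carries wide uncertainty. Compound 3 is therefore estimated in this assay at 6000 nM, with a range from 1200 nM to 40000 nM.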

Compound 3, half-maximal inhibitory concentration: 4330 nM
Compound 3: middle estimate off by 1.4-fold (0.14 log units), on the high side; low and high end bracket the measured number.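

In this assay, going by these compounds alone, the exchange of one halogen for another on an aromatic carbon, para to a large group, gives a 3.9-fold higher number from compound 2 to compound 3 (0.59 log units; beyond the scatter): a modest step, and the first here between two groups that both return a measured number. The change from methyl to fluoro gives an at least 11-fold lower number from compound 1 to compound 3 (1.06 log units; beyond the scatter), so this step is large, and both halogens now stand well apart from methyl at this place, with bromo giving the lower number of the two. The full size of each step away from the methyl compound cannot be read, because one end of each is a limit, not a number: the limit of > 50000 nM in this assay, at which 1 of the 3 values shown sits.

The compounds shown leave open whether chloro or iodo would fall within the range set by the two halogens here, and whether a group of another kind at this place, such as an amine, a nitrile or a carboxylic acid, would give a number near theirs or return to the limit. They also leave open whether the gap between bromo and fluoro would hold if another part of the shared core were changed.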